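A few compounds are considered here, and "the series" means these few. Any claim that something is new, unique, unknown or untested is made for them only; others in the source may bear on it.

Measured compounds:
- compound 1 `COc1cc(/C=C/C(=O)c2ccccc2NC(=O)NS(=O)(=O)c2ccc(C)cc2)ccc1O` — in an ADME assay on the whole organism for cytotoxicity, with Artemia salina as the target, with a stated time of 24 h (a lower number here means that less compound is needed, a higher number that more compound is needed for the effect), compound 1 gives 17.8 ug/mL
- compound 2 `C=CCOc1ccc(/C=C/C(=O)c2ccccc2NC(=O)NS(=O)(=O)c2ccc(C)cc2)cc1` — in this assay compound 2 gives 6.11 ug/mL

For the measured compounds named here, compound 2 holds the lowest of the two numbers so far; its nearest neighbour is compound 1, and the only measured step, a 2.9-fold lower number from compound 1 to compound 2 (0.46 log units; beyond the scatter), separates them. Compound 3 `Cc1ccc(S(=O)(=O)NC(=O)Nc2ccccc2C(=O)/C=C/c2cccnc2)cc1` is the next member of the series and has not yet been measured. It differs from compound 2 in one place: pyridin-3-yl in place of 4-(allyloxy)phenyl on a double-bonded chain carbon bound to a double-bonded chain carbon. Going by the values given here, the one step on record touches the same position, but it exchanged one aryl group for another rather than introducing a pyridin-3-yl, so it does not cover this change directly. Among the compounds with values here, the series gives no further step to lean on, and the size of the earlier step is the only guide to how much that position can move the number. The author therefore expects a modest move, if any, rather than a large one, and takes a step of a 1.8-fold higher number from compound 2 to compound 3 (0.26 log units; within the scatter) as the likely outcome. On that basis compound 3 is estimated at 11 ug/mL, with a range from 4.5 ug/mL to 28 ug/mL.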

Compound 3, concentration for half-maximal effect: 14.1 ug/mL
The estimate for compound 3 lay 1.3-fold (0.11 log units) below the measured number; measured number inside the range.
By their numbers in this assay, from the lowest: compound 2; then compounds 3 and 1 (each within the scatter of the next).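

In this assay, the place on a double-bonded chain carbon bound to a double-bonded chain carbon now carries a ring with a hetero atom, and the step of a 2.3-fold higher number from compound 2 to compound 3 (0.36 log units; beyond the scatter) shows that the number also responds when 4-(allyloxy)phenyl gives way to this smaller pyridin-3-yl group. The step of a 1.3-fold lower number from compound 1 to compound 3 (0.10 log units; within the scatter) shows that pyridin-3-yl and 4-hydroxy-3-methoxyphenyl cannot be told apart here, although the two groups differ in more than one feature, so among the three groups only 4-(allyloxy)phenyl stands apart, with its steps to both others beyond the scatter. Nothing available gives a reason for these numbers.

The compounds shown leave open whether the lower number of compound 2 belongs to the allyl chain of 4-(allyloxy)phenyl or to the ring that carries it, a question that a plain phenyl or a 4-methoxyphenyl at this place would address. They also leave open whether the place of the ring nitrogen matters, as pyridin-4-yl would show, and how a ring bearing an amine or a carboxylic acid would read.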